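This account rests on a few compounds, and the source may have more. Where it says the series, first, only, none or still open, it means among the compounds named here.

Compound 1 `FC(F)(F)c1ccc(Nc2nc(N3CCC3)nc3sc(Nc4c(Cl)cccc4Cl)nc23)cc1` gives 25 nM in a functional assay on HEK293 cells for antagonist activity at transient receptor potential cation channel subfamily V member 1 (Rattus norvegicus), read by calcium flux; on this read-out higher numbers stand for weaker inhibition and lower numbers for stronger inhibition.
Compound 2 `FC(F)(F)c1ccc(Nc2nc(N3CCNCC3)nc3sc(Nc4c(Cl)cccc4Cl)nc23)cc1` reaches only the limit of this assay, > 5000 nM, so no number is known for it.
Compound 3 `CC(C)N1CCN(c2nc(Nc3ccc(C(F)(F)F)cc3)c3nc(Nc4c(Cl)cccc4Cl)sc3n2)CC1` gives 119 nM in this assay.

Among these three, compound 3 holds the highest number that is a real measurement; compound 1 lies a clear step lower (a 4.8-fold higher number from compound 1 to compound 3 (0.68 log units; beyond the scatter)), and compound 2 sits at a limit (the limit of > 5000 nM in this assay, at which 1 of the 3 values shown sits). Compound 4 `CC(C)CNc1nc(Nc2ccc(C(F)(F)F)cc2)c2nc(Nc3c(Cl)cccc3Cl)sc2n1` has not yet been measured. It differs from compound 3 in one place: isobutylamino in place of 4-isopropylpiperazin-1-yl on an aromatic carbon.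

For the measured compounds named here, three measured steps touch this position of the shared core. Swapping the small azetidine ring for a plain piperazine ring was a large loss (an at least 200-fold higher number from compound 1 to compound 2 (2.30 log units; beyond the scatter)), putting an isopropyl on that ring nitrogen recovered most of it (an at least 42-fold lower number from compound 2 to compound 3 (1.62 log units; beyond the scatter)), and the net change from compound 1 to compound 3 was modest (a 4.8-fold higher number from compound 1 to compound 3 (0.68 log units; beyond the scatter)). None of these steps replaces the ring with an open chain, so the direction for compound 4 is uncertain. Since the open isobutylamino group is closer in size to the azetidine of compound 1 than to the large piperazine of compound 3, a modest improvement in this assay is expected for compound 4, namely a 2.0-fold lower number from compound 3 to compound 4 (0.30 log units; within the scatter). Compound 4 is therefore estimated at 60 nM, with a likely range from 10 nM to 400 nM.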

Compound 4, half-maximal inhibitory concentration: 1 nM
The estimate for compound 4 lay 60-fold (1.78 log units) above the measured number; the whole stated range lies above it.
By their numbers in this assay, from the lowest: compound 4; then compound 1; then compound 3. At a limit, above all of these: compound 2.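

The open chain reaches further than either ring-bearing compound with a real number: in this assay, isobutylamino on the aromatic carbon between two ring nitrogen atoms gives a 120-fold lower number from compound 3 to compound 4 (2.08 log units; beyond the scatter) and a 25-fold lower number from compound 1 to compound 4 (1.40 log units; beyond the scatter), so a ring at this position is not needed for strong inhibition, and the earlier gain from adding isopropyl to the piperazine now looks like only a partial recovery. Compound 2 stands at a limit rather than a number: the limit of > 5000 nM in this assay, at which 1 of the 4 values shown sits. Set against that limit, the change is an at least 5000-fold lower number from compound 2 to compound 4 (3.69 log units; beyond the scatter), which makes this single position able to move the result across a very wide span while the rest of the molecule stays the same.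

For the compounds shown here, one open chain cannot show whether the gain comes from losing the ring or from the hydrogen kept on the attached nitrogen, since isobutylamino is the only group here that carries a hydrogen-bond donor at that nitrogen. A dimethylamino group would help separate those two changes, while ethylamino and a longer chain such as hexylamino would show how much chain length matters.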